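Swapping a Dimethylphenyl for a Chlorophenyl on the Urea Nitrogen

The compounds below may be only part of what the source reports. "The series", "measured", "known", "first", "only" and "open" are said of these compounds alone.

Compound 1 `CCN1CCc2c(c(C)nn2C(=O)Nc2ccc(Cl)cc2)C1` — 7.5%
Compound 2 `CCN1CCc2c(c(C(C)(C)C)nn2C(=O)Nc2cc(C)ccc2C)C1` — 15.7%
Compound 3 `CCN1CCc2c(c(C(C)(C)C)nn2C(=O)Nc2ccc(C)cc2C)C1` — 59.9%

These three compounds share a core and were tested in a functional assay on the whole organism (strain Swiss albino) for inhibition, with Mus musculus as the target, in the formalin test, with a stated time of 30 min, at a dose of 100 mg/kg; on this read-out lower numbers stand for less inhibition and higher numbers for more inhibition at the one dose given (going by the name of the read-out). Compound 3 stands highest of the three: in this assay compound 3 gives 59.9%, while compound 2 gives 15.7% and compound 1 gives 7.5%, both lying beyond the scatter below compound 3.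

Compound 4 `CCN1CCc2c(c(C(C)(C)C)nn2C(=O)Nc2ccc(Cl)cc2)C1` has not yet been measured. It differs from compound 3 in one place: 4-chlorophenyl in place of 2,4-dimethylphenyl on an amide-type nitrogen.

Among the measured compounds shown here, only one measured step bears on this change. The step of a number 44.2 percentage points higher from compound 2 to compound 3 (beyond the scatter) shows that shifting the substituents on the phenyl attached to the amide-type nitrogen can move the read-out a great deal. For the measured compounds named here, no step directly covers the exchange of 2,4-dimethylphenyl for 4-chlorophenyl; compound 1 carries the same 4-chlorophenyl as compound 4 but also differs from it elsewhere on the core, so its value can only be noted, and it is the lowest of the three.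

Given that, a drop from compound 3 is expected, of roughly a number 37.9 percentage points lower from compound 3 to compound 4 (beyond the scatter). Compound 4 is therefore estimated at 22%, within the range 5% to 45%.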

Compound 4, a percentage reported as inhibition, in the whole organism at one dose (the size of the read-out at that dose, not a potency): 68.3%
Estimate against measurement, compound 4: 46.3 percentage points below, and the stated range ends below it.
By their numbers in this assay, from the lowest: compounds 1 and 2 (each within the scatter of the next); then compounds 3 and 4 (each within the scatter of the next).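

In this assay, 4-chlorophenyl in place of 2,4-dimethylphenyl on the amide-type nitrogen gives a number 8.4 percentage points higher from compound 3 to compound 4 (within the scatter), so these two groups cannot be told apart here, whereas the same 4-chlorophenyl in place of 2,5-dimethylphenyl gives a number 52.6 percentage points higher from compound 2 to compound 4 (beyond the scatter); of the three groups compared at this place on the tert-butyl compounds, only the 2,5-dimethylphenyl of compound 2 stands apart. The 4-chlorophenyl group alone therefore does not go with a low number, since tert-butyl in place of methyl on an aromatic carbon, with that group kept, gives a number 60.8 percentage points higher from compound 1 to compound 4 (beyond the scatter), which makes the change at this second place a large one as well. Nothing measured here offers a reason for any of these steps.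

Still open, from the compounds shown here alone, is how a plain phenyl or a 4-methoxyphenyl on the amide-type nitrogen would read, and whether an isopropyl group in place of tert-butyl would give a number nearer that of compound 1 or that of compound 4. With a single dose of each compound, these numbers also leave open how the compounds would compare across a range of doses.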